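Limits only: the step to compound 4

The source may hold more compounds than are shown below. What is called first, only, known or untested is meant among the compounds shown, and "the series" means these compounds.

Values in an ADME assay on MT4 cells (Homo sapiens) for cytotoxicity, read by MTT assay; on this read-out lower numbers stand for higher toxicity in this test and higher numbers for lower toxicity in this test:
compound 1 `O=C(CSc1nnnn1-c1cccc2ccccc12)N/N=C/c1ccco1`: > 330000 nM
compound 2 `O=C(CSc1nnnn1-c1cccc2ccccc12)N/N=C/c1ccc(Cl)cc1`: > 295000 nM
compound 3 `O=C(CSc1nnnn1-c1cccc2ccccc12)N/N=C/c1ccc(F)cc1`: > 307000 nM

Each of these values is a limit and not a number. Compound 3 sits at the limit of > 307000 nM in this assay, at which 1 of the 3 values shown sits. Compound 1 and compound 2 likewise give only limits, so compound 3 cannot be ranked against them.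

Compound 4 `Cc1cccc(/C=N/NC(=O)CSc2nnnn2-c2cccc3ccccc23)c1` differs from compound 3 by one change: 3-methylphenyl in place of 4-fluorophenyl on a carbon with a double bond to nitrogen. In words, this is 3-methylphenyl in place of 4-fluorophenyl on a carbon with a double bond to nitrogen.

For the measured compounds named here, three measured steps bear on it: a step that the two limits leave unreadable from compound 1 to compound 3, a step that the two limits leave unreadable from compound 1 to compound 2 and a step that the two limits leave unreadable from compound 2 to compound 3. None of them has a readable size, so none points in a direction. The expectation rests on compound 3 at > 307000 nM, a limit. In this assay no step beyond the scatter is expected, and the expected step is a step that the limit leaves unreadable from compound 3 to compound 4. For compound 4 the estimate is 310000 nM, with an expected range from 200000 nM to 340000 nM, most likely reported as a limit again.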

Compound 4, half-maximal cytotoxic concentration: 269000 nM
For compound 4 the middle estimate is 1.2-fold (0.06 log units) above the measured one, within the range that was stated.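

In this assay compound 4, with 3-methylphenyl on the carbon with a double bond to nitrogen, gives a number, whereas compound 1, compound 2 and compound 3 give only limits, so this position now has its first readable steps. These are an at least 1.1-fold lower number from compound 3 to compound 4 (0.05 log units; that floor lies within the scatter), an at least 1.0-fold lower number from compound 2 to compound 4 (0.04 log units; that floor lies within the scatter) and an at least 1.2-fold lower number from compound 1 to compound 4 (0.08 log units; that floor lies within the scatter). Each is only a floor set by a limit, so these steps do not separate 3-methylphenyl from 4-fluorophenyl, 4-chlorophenyl or furan-2-yl.

On these data alone, the full size of all three steps stays open, since only limits stand on one side of them. Also open, as far as these compounds go, is how a phenyl group carrying an amine or a carboxylic acid would read in this assay in place of 3-methylphenyl.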